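Allylic hydroxyl on the side chain of compound 2

The source may report more compounds than this note shows. Statements on the series, on what has been measured and on what is new or still open speak of the compounds shown alone.

Compound 1 `O=C(O)c1csc([C@H]2CC[C@@H]3[C@@H](/C=C/COc4ccccc4)[C@H](O)C[C@@H]3O2)n1` carries a phenoxy group on the saturated chain carbon bound to the double-bonded chain carbon. In a functional assay on CHO cells for agonist activity at prostacyclin receptor (Homo sapiens), read by HTRF and cAMP accumulation, with a stated time of 30 min (a higher number here means that more compound is needed for the effect, a lower number that less compound is needed), compound 1 reaches only the assay limit, > 10000 nM. Compound 2 `O=C(O)c1csc([C@H]2CC[C@@H]3[C@@H](/C=C/CCCOc4ccccc4)[C@H](O)C[C@@H]3O2)n1` has 2-phenoxyethyl in place of phenoxy at that position. In this assay compound 2 likewise sits at the assay limit, > 10000 nM. The step that the two limits leave unreadable from compound 1 to compound 2 is therefore unreadable, since the limit of > 10000 nM in this assay, at which 2 of the 2 values shown sit, covers both values shown, and compound 2 stands at that limit with no number of its own.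

Compound 3 `O=C(O)c1csc([C@H]2CC[C@@H]3[C@@H](/C=C/[C@@H](O)COc4ccccc4)[C@H](O)C[C@@H]3O2)n1` differs from compound 2 by 1-hydroxy-2-phenoxyethyl in place of 3-phenoxypropyl on a double-bonded chain carbon bound to a double-bonded chain carbon. Going by the values given here, no measured step bears on this change: the only step, a step that the two limits leave unreadable from compound 1 to compound 2, has no readable size. The direction of the step of an at least 3.3-fold lower number from compound 2 to compound 3 (0.52 log units; beyond the scatter) in this assay is thus an estimate without precedent in the series, and a reported limit remains as likely as a number. Compound 3 is expected to give 3000 nM in this assay, within 100 nM to 10000 nM.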

Compound 3, half-maximal effective concentration: 11 nM
For compound 3 the middle estimate is 270-fold (2.44 log units) above the measured one; measured number outside the range, below it.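

In this assay, the side chain now gives a measurable response: 1-hydroxy-2-phenoxyethyl gives an at least 900-fold lower number from compound 2 to compound 3 (2.95 log units; beyond the scatter) against 3-phenoxypropyl, and an at least 900-fold lower number from compound 1 to compound 3 (2.95 log units; beyond the scatter) against phenoxymethyl. The leaving 3-phenoxypropyl and entering 1-hydroxy-2-phenoxyethyl have the same heavy-atom count, so the large step from the former comes with a change in composition rather than in group size; the entering group also adds a hydrogen-bond donor and a defined stereocentre. Both steps are minimum sizes, because compound 1 and compound 2 give only limits: the limit of > 10000 nM in this assay, at which 2 of the 3 values shown sit.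

Which feature of the entering group goes with the step stays open, as the hydroxyl and the defined stereocentre arrive together in compound 3. Whether the opposite configuration at the hydroxyl-bearing carbon, or a methoxy or an amine in place of the hydroxyl, would keep a value near that of compound 3 is also unresolved.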